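The source may report more compounds than this note shows. Statements on the series, on what has been measured and on what is new or still open speak of the compounds shown alone.

Measured so far in the one assay used:
compound 1, `CN(c1ccc(Oc2ncnc3sccc23)cc1)c1nccc(N2CCc3ccccc3C2)n1`: 24.3%
compound 2, `CN(c1ccc(Oc2ncnc3ccsc23)cc1)c1nccc(N2CCc3ccccc3C2)n1`: 30.2%

In a functional assay on MDA-MB-231 cells (Homo sapiens) for inhibition, read by MTT assay, with a stated time of 72 h, tested at 20 uM (a higher number here means more inhibition at the concentration tested (going by the name of the read-out), a lower number less inhibition), compound 1 gives 24.3%, the lower of the two numbers, and compound 2 gives 30.2%. Among the compounds with values here, the only step between measured compounds, a number 5.9 percentage points higher from compound 1 to compound 2 (within the scatter), exchanges the group carried by the aromatic oxygen, and since it lies within the scatter the two compounds cannot be told apart on this read-out.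

Compound 3 `CN(c1ccc(Oc2ncnc3sccc23)cc1)c1nccc(N2CCCCC2)n1` shares the core of compound 1 and differs from it at the amine on the aromatic carbon: piperidin-1-yl in place of 1,2,3,4-tetrahydroisoquinolin-2-yl on an aromatic carbon. Within the data shown here, no measured step bears on this position. The step from compound 1 to compound 2 concerns a different part of the molecule and gives no guidance on losing the six-membered aromatic ring of carbon only that belongs to the 1,2,3,4-tetrahydroisoquinolin-2-yl group. The expectation for compound 3 therefore rests on the value of compound 1 alone, with a wide range and no direction beyond the scatter.

Compound 3 is expected to give about 20% in this assay, between 5% and 40%, which is an expected step of a number 4.3 percentage points lower from compound 1 to compound 3 (within the scatter).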

Compound 3, a percentage reported as inhibition, at one concentration (the size of the read-out at that concentration, not a potency): 29.3%
The estimate for compound 3 lay 9.3 percentage points below the measured number, and the stated range covers the measured number.
By their numbers in this assay, from the lowest: compounds 1, 3 and 2 (each within the scatter of the next).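

Within the data shown here, this is the first measured step at the amine on the aromatic carbon, and in this assay the exchange of 1,2,3,4-tetrahydroisoquinolin-2-yl for piperidin-1-yl gives a number 5 percentage points higher from compound 1 to compound 3 (within the scatter), so this read-out does not separate the two groups. The six-membered aromatic ring of carbon only that belongs to 1,2,3,4-tetrahydroisoquinolin-2-yl is therefore not required to keep the number at the level of compound 1, although this holds only for one cell line at one tested concentration, and the read-out is not a potency. Nothing on hand accounts for the two groups reading alike, and no measurement of any property of either group is available to interpret the result.

The compounds shown leave open what number amines of another kind at this position, such as morpholin-4-yl, dimethylamino or an unsubstituted amino group, would give, and whether one of these would move the number beyond the scatter. They also leave open whether piperidin-1-yl would read the same way on the core of compound 2, since that pairing of the two changes is not among the compounds shown here.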